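Selenol-to-thiol swap in an anilinomethyl quinazoline series

The source may report more compounds than this note shows. Statements on the series, on what has been measured and on what is new or still open speak of the compounds shown alone.

Measured so far in a functional assay on MCF7 cells (Homo sapiens) for cytotoxicity, read by MTT assay, with a stated time of 72 h; a higher number here means a weaker inhibitor of growth, a lower number a stronger inhibitor of growth:
Compound 1 `COc1ccc(CNc2nc([SeH])nc3ccccc23)cc1`: 94000 nM
Compound 2 `CSc1ccc(CNc2nc([SeH])nc3ccccc23)cc1`: > 100000 nM, a limit of the assay, not a number.
Compound 3 `[SeH]c1nc(NCc2ccccc2)c2ccccc2n1`: > 100000 nM, likewise a limit of the assay.

For the measured compounds named here, compound 1 holds the only real number in this assay; the other two values sit at the limit of > 100000 nM in this assay, at which 2 of the 3 values shown sit. The steps of an at least 1.0-fold higher number from compound 1 to compound 2 (0.02 log units; that floor lies within the scatter) and an at least 1.0-fold higher number from compound 1 to compound 3 (0.02 log units; that floor lies within the scatter) both alter the group on the benzyl ring and leave the selenol untouched, so neither bears directly on the change to compound 4 `COc1ccc(CNc2nc(S)nc3ccccc23)cc1`, which is one sulfur atom in place of one selenium atom, on an aromatic carbon. Going by the values given here, with no measured step on this position, the expectation for compound 4 is a number near that of compound 1 or a limit, giving an estimated step of a 1.6-fold higher number from compound 1 to compound 4 (0.20 log units; within the scatter). Compound 4 is therefore estimated at 150000 nM, within 60000 nM to 400000 nM.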

Compound 4, concentration for total growth inhibition: 36500 nM
Compound 4: middle estimate off by 4.1-fold (0.61 log units), on the high side; the measured number lies below the stated range.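

In this assay, the aromatic carbon between two ring nitrogen atoms responds to the atom placed on it: one sulfur atom in place of one selenium atom gives a 2.6-fold lower number from compound 1 to compound 4 (0.41 log units; beyond the scatter). For the compounds shown here, this is the only step here with a real number at both ends, and the methoxy group stays fixed across it. The earlier steps on the benzyl ring give only floors within the scatter or cannot be read: the limit of > 100000 nM in this assay, at which 2 of the 4 values shown sit.

On these data alone, whether sulfur gives a similar step with methylsulfanyl or hydrogen on the benzyl ring remains open. So does the reading for an amine or a methyl ether on this aromatic carbon.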